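Chloro substitution on the ester-bearing ring of compound 3

The compounds below may be only part of what the source reports. "The series", "measured", "known", "first", "only" and "open" are said of these compounds alone.

Compound 3 `COC(=O)c1ccccc1OC(=O)COc1cc(O)c2c(=O)cc(-c3ccccc3)oc2c1` is the unsubstituted reference of the three measured aryl esters. In an ADME assay on cells (T-cell, Mus musculus, strain BALB/c) for cytotoxicity, read by MTT assay, with a stated time of 48 h (on this read-out higher numbers stand for lower toxicity in this test and lower numbers for higher toxicity in this test), compound 3 gives 265000 nM. Compound 1 `COC(=O)c1cc(O)ccc1OC(=O)COc1cc(O)c2c(=O)cc(-c3ccccc3)oc2c1` gives 263000 nM, and compound 2 `COC(=O)c1cccc(Cl)c1OC(=O)COc1cc(O)c2c(=O)cc(-c3ccccc3)oc2c1` gives 366000 nM. Compound 3 stands second highest of the three numbers; its steps to both neighbours are within the scatter: a 1.0-fold higher number from compound 1 to compound 3 (0.00 log units; within the scatter) and a 1.4-fold lower number from compound 2 to compound 3 (0.14 log units; within the scatter). The three compounds are therefore indistinguishable in this read-out.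

Compound 4 `COC(=O)c1cc(Cl)ccc1OC(=O)COc1cc(O)c2c(=O)cc(-c3ccccc3)oc2c1` is not yet measured. Its change from compound 3 is chloro in place of hydrogen on an aromatic carbon. The step that bears on it most directly is the reverse of a 1.4-fold lower number from compound 2 to compound 3 (0.14 log units; within the scatter), a chloro at another position of the same ring, which moved nothing beyond the scatter; the hydroxy-to-hydrogen step a 1.0-fold higher number from compound 1 to compound 3 (0.00 log units; within the scatter) was equally flat. Compound 4 is therefore expected to sit within the scatter of compound 3, with the estimated step of a 1.1-fold higher number from compound 3 to compound 4 (0.05 log units; within the scatter). The estimate for compound 4 is 300000 nM, with a range of 150000 nM to 600000 nM.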

Compound 4, half-maximal cytotoxic concentration: > 436000 nM
Compound 4 ended at the assay's limit (the forecaster's own chance of this, stated with the estimate: 10%); at least 1.4-fold (0.16 log units) between middle value and limit.
By their numbers in this assay, from the lowest: compounds 1, 3 and 2 (each within the scatter of the next). At a limit, above all of these: compound 4.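

In this assay compound 4 gives > 436000 nM, a limit of the assay and not a number, and it is the only compound shown that ends at this limit: the limit of > 436000 nM in this assay, at which 1 of the 4 values shown sits. As far as these compounds go, at this position, para to a large group, chloro in place of hydrogen gives an at least 1.6-fold higher number from compound 3 to compound 4 (0.21 log units; that floor lies within the scatter), and chloro in place of hydroxy gives an at least 1.6-fold higher number from compound 1 to compound 4 (0.21 log units; that floor lies within the scatter), so neither step is established as beyond the scatter, though both remain open upward. The 4-chloro-2-(methoxycarbonyl)phenyl group in place of the 2-chloro-6-(methoxycarbonyl)phenyl group gives an at least 1.1-fold higher number from compound 2 to compound 4 (0.07 log units; that floor lies within the scatter), so the two chloro placements are not separated on this read-out.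

From the compounds shown here alone, the actual number for compound 4 remains open, and with it the true size of all three steps. Going by these compounds, how an amine or a carboxylic acid at this position would read in this assay also remains open.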